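Second fluoro on the benzoyl ring of compound 3

The compounds below may be only part of what the source reports. "The series", "measured", "known", "first", "only" and "open" are said of these compounds alone.

Going by the values given here, compound 3 `CC1(C)C=C(n2ccccc2=O)c2cc(C(=O)c3ccccc3F)ccc2O1` gives 6.34 in a functional assay (trachea) with Rattus norvegicus as the target (on this read-out lower numbers stand for lower potency and higher numbers for higher potency (the scale is a negative logarithm)), and stands second highest of the three numbers known. Its nearest neighbour is compound 2 `CC1(C)C=C(n2ccccc2=O)c2cc(C(=O)c3ccccc3)ccc2O1` at 6.21, the gap being a number 0.13 log units higher from compound 2 to compound 3 (within the scatter); furthest is compound 1 `CC(=O)c1ccc2c(c1)C(n1ccccc1=O)=CC(C)(C)O2` at 6.65, the gap being a number 0.31 log units lower from compound 1 to compound 3 (beyond the scatter). Compound 4 `CC1(C)C=C(n2ccccc2=O)c2cc(C(=O)c3c(F)cccc3F)ccc2O1` differs from compound 3 by fluoro in place of hydrogen on an aromatic carbon. Among the compounds with values here, the only step that bears on it is the earlier a number 0.13 log units higher from compound 2 to compound 3 (within the scatter), which introduced the first fluoro and stayed within the scatter. On that basis a step of no more than the scatter is expected, with a number 0.06 log units higher from compound 3 to compound 4 (within the scatter) as the estimated change. Compound 4 is therefore estimated at 6.4, between 6 and 6.8.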

Compound 4, logarithm of the reciprocal of the active concentration, log(1/C): 5.99
Beside the measured number, compound 4's estimate is 0.41 log units above it; measured number below the stated range.
By their numbers in this assay, from the lowest: compounds 4, 2 and 3 (each within the scatter of the next, the first and the last beyond it); then compound 1.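

Unlike the first fluoro, the second moves the number beyond the scatter (a number 0.35 log units lower from compound 3 to compound 4 (beyond the scatter)), so the two fluoro steps on this ring do not behave alike. Set against the plain phenyl ketone, the 2,6-difluorophenyl group stays within the scatter (a number 0.22 log units lower from compound 2 to compound 4 (within the scatter)), while set against methyl on the carbonyl carbon it gives the largest gap in the series (a number 0.66 log units lower from compound 1 to compound 4 (beyond the scatter)). Nothing measured accounts for this difference. From the compounds shown here alone, what a chloro, methoxy or amino group in place of the second fluoro would give remains open.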